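The source may report more compounds than this note shows. Statements on the series, on what has been measured and on what is new or still open speak of the compounds shown alone.

Working notes on the series. The shared core is held by compound 1 `CC(C)(C)c1cc(OC(=O)/C=C/c2ccccc2)ccc1O` and compound 2 `CC(C)(C)c1cc(OC(=O)c2ccco2)ccc1O`, which differ only in the group on the carbonyl carbon. In an assay on isolated protein for antagonist activity at Bile acid receptor (Homo sapiens), read by HTRF, with a stated time of 30 min (on this read-out lower numbers stand for stronger inhibition and higher numbers for weaker inhibition), compound 1 gives > 100000 nM, a limit of the assay and not a number. In this assay compound 2 gives > 100000 nM, again a limit of the assay rather than a measured value. Compound 2 thus stands at the limit of > 100000 nM in this assay, at which 2 of the 2 values shown sit, with nothing in the set to rank it against.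

Compound 3 `CC(C)(C)c1cc(OC(=O)c2ccc(Cl)cc2)ccc1O` carries the change (4-chlorophenyl in place of furan-2-yl on a carbonyl carbon). Going by the values given here, no step between measured compounds exists here, so no measured direction is available for this assay. The expected step is a number no higher from compound 2 to compound 3 (the limit leaves the size open), that is, none beyond the scatter, with compound 3 most likely reported again only as a limit. Compound 3 is expected to give about 100000 nM, within 30000 nM to 300000 nM.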

Compound 3, half-maximal inhibitory concentration: > 100000 nM
Compound 3: only a limit was reported; the forecaster's own chance of this, stated with the estimate: 80%; the middle value sits exactly at the limit.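

In this assay compound 3 gives > 100000 nM, again a limit of the assay and not a number. The step from compound 2 to compound 3 therefore cannot be read. The compounds shown leave open whether any group on the carbonyl carbon gives a measurable value: the limit of > 100000 nM in this assay, at which 3 of the 3 values shown sit.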